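A Catechol Swap Tested on a Thiophene Sulfonamide Series

The source may report more compounds than this note shows. Statements on the series, on what has been measured and on what is new or still open speak of the compounds shown alone.

Three compounds from one study were tested in a functional assay on HeLa cells (Homo sapiens) for inhibition, read by CCK-8 assay, with a stated time of 48 h; on this read-out higher numbers stand for weaker inhibition and lower numbers for stronger inhibition. Compound 1 `O=C(Nc1cccc([N+](=O)[O-])c1)N1CCN(S(=O)(=O)c2sccc2-c2ccccc2Oc2ccc(O)c(O)c2)CC1` and compound 2 `COc1ccc(Oc2ccccc2-c2ccsc2S(=O)(=O)N2CCN(C(=O)Nc3cccc([N+](=O)[O-])c3)CC2)cc1OC` share a core that carries a nitrophenyl urea on a piperazine, while compound 3 `COc1ccc(Oc2ccc(C(C)C)cc2-c2ccsc2S(=O)(=O)NCCNC(=S)Nc2cc(C(F)(F)F)cc(C(F)(F)F)c2)cc1OC` has a different core; the difference between the two cores is not broken down here. Compound 4 `CC(C)c1ccc(Oc2ccc(O)c(O)c2)c(-c2ccsc2S(=O)(=O)NCCNC(=S)Nc2cc(C(F)(F)F)cc(C(F)(F)F)c2)c1` has not yet been measured.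

For compound 1, this assay reports only a limit, > 20000 nM, which is not a number. For compound 2, this assay likewise reports only a limit, > 50000 nM. The change between them is 3,4-dihydroxyphenyl in place of 3,4-dimethoxyphenyl on an oxygen on an aromatic ring, and because both values are limits the limit of > 20000 nM in this assay, at which 1 of the 3 values shown sits, the limit of > 50000 nM in this assay, at which 1 of the 3 values shown sits, the result is a step that the two limits leave unreadable from compound 2 to compound 1. For the measured compounds named here, compound 3 is the one compound with a measured number: in this assay compound 3 gives 8300 nM.

The change from compound 3 to compound 4 is the same change, (3,4-dihydroxyphenyl in place of 3,4-dimethoxyphenyl on an oxygen on an aromatic ring), made on a different core. Going by the values given here, since the only earlier example of this change is unreadable, the expectation for compound 4 rests on compound 3 alone with its value of 8300 nM. The step is expected to be a 1.1-fold higher number from compound 3 to compound 4 (0.04 log units; within the scatter), meaning little change is assumed. Compound 4 is therefore estimated to give 9000 nM, with a range from 2500 nM to 40000 nM.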

Compound 4, half-maximal inhibitory concentration: > 20000 nM
Compound 4: no number, only a limit; the forecaster's own chance of this, stated with the estimate: 30%; middle value at least 2.2-fold (0.34 log units) away from the limit.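

In this assay compound 4 gives > 20000 nM, which is a limit of the assay and not a number. Placing 3,4-dihydroxyphenyl where 3,4-dimethoxyphenyl stood on the oxygen gives an at least 2.4-fold higher number from compound 3 to compound 4 (0.38 log units; beyond the scatter), so on the core of compound 3 this change weakens inhibition, although only the minimum size of the loss is known. The same change on the core shared by compound 1 and compound 2 cannot be read, as both carry limits, so this series offers one readable example of the change, and nothing shows whether the loss carries over from one core to the other.

On these data alone, the exact value of compound 4 remains open, and so does the question of whether the loss requires both hydroxyl groups or merely the removal of the methyl groups from the 3,4-dimethoxyphenyl group. A phenyl ring carrying a single hydroxyl group or a carboxylic acid at this place, compared on the core of compound 3, would be a direct way to separate those possibilities.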